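The source may hold more compounds than are shown below. What is called first, only, known or untested is meant among the compounds shown, and "the series" means these compounds.

Compound 1 `Cc1ccc(/C=C2\CN(Cc3cn(Cc4cccc(Cl)c4)nn3)C/C(=C\c3ccc(C)cc3)C2=O)cc1`: 29300 nM
Compound 2 `O=C1/C(=C/c2ccccc2F)CN(Cc2cn(Cc3ccc(F)cc3)nn2)C/C1=C\c1ccccc1F`: 6400 nM

In a functional assay on 4T1 cells (Mus musculus) for cytotoxicity, read by MTT assay, with a stated time of 24 h (on this read-out lower numbers stand for stronger inhibition and higher numbers for weaker inhibition), compound 1 gives 29300 nM, the higher of the two numbers and so the weaker result. Compound 2, at 6400 nM, lies lower by more than the usual scatter. These two compounds differ in more than one place, so their gap does not isolate any single change.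

Compound 3 `Cc1ccc(/C=C2\CN(Cc3cn(Cc4ccccc4Cl)nn3)C/C(=C\c3ccc(C)cc3)C2=O)cc1` changes one thing in compound 1, turning 3-chlorobenzyl into 2-chlorobenzyl: 2-chlorophenyl in place of 3-chlorophenyl on a saturated chain carbon bound to an aromatic nitrogen. The atoms stay the same but are joined differently. For the measured compounds named here, no measured pair shows a change of this kind, so the data offer no direct guide. The expectation therefore rests on compound 1 at 29300 nM, its closest relative, and no shift beyond the scatter is expected in this assay. The expected size of a 1.3-fold lower number from compound 1 to compound 3 (0.11 log units; within the scatter) is small, leaning slightly towards a lower number. Compound 3 is expected at 23000 nM, within an estimated range of 9000 nM to 55000 nM.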

Compound 3, half-maximal inhibitory concentration: 23200 nM
For compound 3 the middle estimate is 1.0-fold (0.00 log units) below the measured one; low and high end bracket the measured number.
By their numbers in this assay, from the lowest: compound 2; then compounds 3 and 1 (each within the scatter of the next).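

In this assay, putting 2-chlorophenyl in place of 3-chlorophenyl on a saturated chain carbon bound to an aromatic nitrogen gives a 1.3-fold lower number from compound 1 to compound 3 (0.10 log units; within the scatter). This is the first pair among these compounds that differs in one place only, and it shows that these two chlorophenyl groups cannot be told apart here when the rest of compound 1 stays the same. No measurement shown here offers an explanation for this result.

The compounds shown leave open whether a phenyl group carrying a methoxy group, an amine or a carboxylic acid instead of chlorine would also leave the number within the scatter. For the compounds shown here, they also leave open which of its several differences sets compound 2 apart, since no single-place step connects it to compound 1 or compound 3.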